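From (Chloromethyl)carbonyl to Cyclohexyl on an Amide-Type Nitrogen

The compounds below may be only part of what the source reports. "The series", "measured", "known", "first", "only" and "open" are said of these compounds alone.

In a functional assay on K562 cells (Homo sapiens) for antiproliferative activity, read by MTT assay (a lower number here means a stronger inhibitor, a higher number a weaker inhibitor), compound 1 (`O=C1NC(c2ccccc2)CN1S(=O)(=O)c1ccc2c(c1)CCCN2`) gives > 20000 nM which is a limit of the assay and not a number. Compound 2 (`C=CCOC(=O)N1CCCc2cc(S(=O)(=O)N3CC(c4ccccc4)NC3=O)ccc21`) gives 473 nM and compound 3 (`O=C(CCl)NC(=O)N1CCCc2cc(S(=O)(=O)N3CC(c4ccccc4)NC3=O)ccc21`) gives 515 nM so the two stand level, with a 1.1-fold higher number from compound 2 to compound 3 (0.04 log units; within the scatter) as the step between them. Compound 4 (`O=C(NC1CCCCC1)N1CCCc2cc(S(=O)(=O)N3CC(c4ccccc4)NC3=O)ccc21`) carries cyclohexyl in place of (chloromethyl)carbonyl on an amide-type nitrogen. Two large steps show what filling that place gained: an at least 42-fold lower number from compound 1 to compound 2 (1.62 log units; beyond the scatter) with allyloxycarbonyl and an at least 38-fold lower number from compound 1 to compound 3 (1.58 log units; beyond the scatter) with ((chloromethyl)carbonyl)carbamoyl. Compound 4 keeps a substituent there, as cyclohexylcarbamoyl, and the level values of compound 2 and compound 3 show that two quite different outer groups gave the same reading. On these two compounds alone, no step beyond the scatter is expected in this assay and the expected change is a 1.3-fold higher number from compound 3 to compound 4 (0.10 log units; within the scatter) in this estimate. For compound 4 the estimated value is 650 nM in this assay with an expected range from 200 nM to 2500 nM around it.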

Compound 4, half-maximal inhibitory concentration: 813 nM
Beside the measured number, compound 4's estimate is 1.3-fold (0.10 log units) below it, within the range that was stated.
By their numbers in this assay, from the lowest: compounds 2, 3 and 4 (each within the scatter of the next). At a limit, above all of these: compound 1.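

In this assay cyclohexyl in place of (chloromethyl)carbonyl on an amide-type nitrogen gives a small shift (that is, a 1.6-fold higher number from compound 3 to compound 4 (0.20 log units; within the scatter)), and cyclohexylamino in place of allyloxy on a carbonyl carbon gives another (that is, a 1.7-fold higher number from compound 2 to compound 4 (0.24 log units; within the scatter)), so a third outer group, one with a six-membered non-aromatic ring of carbon only and no chlorine, reads level with the other two. The large gain from filling this place also holds for cyclohexylcarbamoyl (that is, an at least 24-fold lower number from compound 1 to compound 4 (1.39 log units; beyond the scatter)). That step has only a lower bound on its size, since the reading for compound 1 is a limit of the assay and not a number: the limit of > 20000 nM in this assay, at which 1 of the 4 values shown sits.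

The compounds shown leave open whether an amine, a carboxylic acid or a longer alkyl chain on this carbamoyl nitrogen would keep the same reading. They also leave open whether a phenyl ring in place of cyclohexyl would do so.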